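A 2-Ethoxyphenyl Amine on the Shared Core

The source may report more compounds than this note shows. Statements on the series, on what has been measured and on what is new or still open speak of the compounds shown alone.

Compound 2 `O=C1C(NC2CC2)=CC(=O)c2c1nc1n2[C@H]2OC[C@@H](O)[C@H]2OC1` carries a cyclopropyl group on the amine nitrogen of the shared core. In a functional assay on MCF7 cells (Homo sapiens) for inhibition, read by sulforhodamine B assay (a lower number here means a stronger inhibitor, a higher number a weaker inhibitor), compound 2 gives only a limit of the assay, > 16000 nM. Its two measured neighbours are known only as limits as well. Compound 1 `CCCc1ccc(NC2=CC(=O)c3c(nc4n3[C@H]3OC[C@@H](O)[C@H]3OC4)C2=O)cc1` gives in this assay a limit of > 4000 nM. Compound 3 `O=C1C(N2CCCCC2)=CC(=O)c2c1nc1n2[C@H]2OC[C@@H](O)[C@H]2OC1` gives in this assay a limit of > 8000 nM. The step that the two limits leave unreadable from compound 1 to compound 2 and the step that the two limits leave unreadable from compound 2 to compound 3 therefore cannot be read, because of the limit of > 16000 nM in this assay, at which 1 of the 3 values shown sits, the limit of > 4000 nM in this assay, at which 1 of the 3 values shown sits, and the limit of > 8000 nM in this assay, at which 1 of the 3 values shown sits, each stop at the edge of what the assay reports.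

Compound 4 `CCOc1ccccc1NC1=CC(=O)c2c(nc3n2[C@H]2OC[C@@H](O)[C@H]2OC3)C1=O` differs from compound 2 in one place: 2-ethoxyphenyl in place of cyclopropyl on an amine nitrogen. For the measured compounds named here, the only measured step that touches the same amine nitrogen, from compound 1 to compound 2, has no readable size, so it gives no direction to expect. Compound 4 is therefore expected to show no step beyond the scatter, an at least 1.3-fold lower number from compound 2 to compound 4 (0.12 log units; that floor lies within the scatter). The estimated value for compound 4 in this assay is 12000 nM, with a range from 3000 nM to 50000 nM, and most likely it will again be reported only as a limit.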

Compound 4, half-maximal inhibitory concentration: > 4000 nM
Compound 4: a limit, no number; the forecaster's own chance of this, stated with the estimate: 75%; the middle value does not contradict the limit.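

In this assay compound 4 gives only a limit, > 4000 nM. For the compounds shown here, no step to compound 4 from compound 1 or compound 2 can be read: all three values are limits. The compounds shown leave open whether 2-ethoxyphenyl, cyclopropyl and 4-propylphenyl on the amine nitrogen differ in inhibition at all.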